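This account rests on a few compounds, and the source may have more. Where it says the series, first, only, none or still open, it means among the compounds named here.

Compound 1 `CCCNS(=O)(=O)c1ccc(Nc2ncc3c(n2)N(c2ccn(C)n2)C(CC)C(=O)N3C)cc1` and compound 2 `CCCCNS(=O)(=O)c1ccc(Nc2ncc3c(n2)N(c2ccn(C)n2)C(CC)C(=O)N3C)cc1` share one core and differ only at the end of a short chain. In an assay for inhibition of serine/threonine-protein kinase PLK2 (Homo sapiens), read by FRET and Z'-LYTE, with a stated time of 1 h (a higher number here means a weaker inhibitor, a lower number a stronger inhibitor), compound 1 gives 190 nM, and compound 2 gives 191 nM. The change between them, (methyl in place of hydrogen on a saturated chain carbon, three bonds along the chain from a sulfonamide nitrogen), made a step of a 1.0-fold higher number from compound 1 to compound 2 (0.00 log units; within the scatter), so lengthening the chain left the result where it was.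

Compound 3 `CCCNC(=O)c1ccc2c(ccn2-c2ncc3c(n2)N(c2ccn(C)n2)C(CC)C(=O)N3C)c1` is built on a different core; how the two cores differ is not broken down here. In this assay compound 3 gives 207 nM. Compound 4 `CCCCNC(=O)c1ccc2c(ccn2-c2ncc3c(n2)N(c2ccn(C)n2)C(CC)C(=O)N3C)c1` has not been measured and differs from compound 3 by methyl in place of hydrogen on a saturated chain carbon, three bonds along the chain from an amide-type nitrogen. For the measured compounds named here, this is the same kind of change as the one from compound 1 to compound 2, but here the saturated chain carbon lies three bonds along the chain from an amide-type nitrogen rather than from a sulfonamide nitrogen. Because the earlier step was a 1.0-fold higher number from compound 1 to compound 2 (0.00 log units; within the scatter), the step from compound 3 to compound 4 is expected to be a 1.0-fold higher number from compound 3 to compound 4 (0.01 log units; within the scatter). Compound 4 is therefore estimated at 210 nM, most likely between 120 nM and 370 nM.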

Compound 4, half-maximal inhibitory concentration: 159 nM
For compound 4 the middle estimate is 1.3-fold (0.12 log units) above the measured one; low and high end bracket the measured number.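

In this assay the propyl to butyl change on the amide chain gave a 1.3-fold lower number from compound 3 to compound 4 (0.11 log units; within the scatter) and so, as on the sulfonamide chain, adding the methyl left the result within the ordinary noise of the measurement. Set side by side, the two steps agree: the same change on two cores in this assay, a 1.0-fold higher number (0.00 log units; within the scatter) from compound 1 to compound 2 and a 1.3-fold lower number (0.11 log units; within the scatter) from compound 3 to compound 4, 1.3-fold (0.12 log units) apart, within the scatter of two such steps

So in this one comparison the change carried from one core to the other, in the sense that it made no clear difference on either. It does not show that the change would behave the same way on other cores, and a change this small is a weak test, since two steps near zero would agree whether or not the cores respond alike.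

The compounds shown leave open whether a longer chain such as pentyl, or a chain ending in an amine or a carboxylic acid, would give matching steps on both cores. They also leave open how a shorter chain such as ethyl would compare.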